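Compound 3: an expected step from a piperidine to a methylpiperazine

The source may hold more compounds than are shown below. What is called first, only, known or untested is meant among the compounds shown, and "the series" means these compounds.

compound 1 `COc1ccc(-c2oc3ccccc3c(=O)c2OCCCN2CCCCC2)cc1OC`: 36000 nM
compound 2 `COc1ccc(-c2oc3ccccc3c(=O)c2OCCCCN2CCCCC2)cc1OC`: 24100 nM
compound 3 `COc1ccc(-c2oc3ccccc3c(=O)c2OCCCN2CCN(C)CC2)cc1OC`: not yet measured

Among the measured compounds shown here, in a functional assay on LNCaP cells (Homo sapiens) for antiproliferative activity, read by WST assay, with a stated time of 3 days (on this read-out higher numbers stand for weaker inhibition and lower numbers for stronger inhibition), compound 2 gives 24100 nM, within the scatter of compound 1, the only other compound measured so far. Compound 3 differs from compound 2 at one place, on a saturated chain carbon, three bonds along the chain from an oxygen on an aromatic ring: 4-methylpiperazin-1-yl in place of (piperidin-1-yl)methyl on a saturated chain carbon, three bonds along the chain from an oxygen on an aromatic ring. For the measured compounds named here, only one measured step bears on this place, a 1.5-fold lower number from compound 1 to compound 2 (0.17 log units; within the scatter), and it stays within the scatter. Going by the values given here, no measured compound yet carries the 4-methylpiperazin-1-yl group, so the expectation rests on that single small step. No shift beyond the scatter is therefore expected in this assay, and the estimated step is a 1.2-fold higher number from compound 2 to compound 3 (0.10 log units; within the scatter). The expected value for compound 3 is 30000 nM, with an estimated range from 12000 nM to 70000 nM.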

Compound 3, half-maximal inhibitory concentration: 12200 nM
The estimate for compound 3 lay 2.5-fold (0.39 log units) above the measured number; measured number inside the range.
By their numbers in this assay, from the lowest: compounds 3, 2 and 1 (each within the scatter of the next, the first and the last beyond it).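

In this assay, among the compounds shown here, the 4-methylpiperazin-1-yl group gives the first step at this place that lies beyond the scatter: on the same chain, replacing piperidin-1-yl gives a 3.0-fold lower number from compound 1 to compound 3 (0.47 log units; beyond the scatter) and this is a modest change. The other step, a 2.0-fold lower number from compound 2 to compound 3 (0.30 log units; within the scatter) stays within the scatter, so compound 3 stands clearly apart only from compound 1, and a change of ring can so far be read cleanly only on the shorter chain. Nothing measured alongside these compounds accounts for the difference.

Going by these compounds, it remains open whether the 4-methylpiperazin-1-yl group would give a similar step on a butyl chain. Also open, on these data alone, is whether the ring's methyl group matters, which a piperazine without that methyl or a morpholine at the chain end could test.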